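This account rests on a few compounds, and the source may have more. Where it says the series, first, only, none or still open, it means among the compounds named here.

Measured compounds:
Compound 1, `COc1cc(OC)c(C(=O)/C=C/c2cn(-c3ccccc3)nc2-c2cccnc2)c(OC)c1`: 1200 nM
Compound 2, `COc1ccc(OC)c(C(=O)/C=C/c2cn(-c3ccccc3)nc2-c2cccnc2)c1`: 2400 nM

In an ADME assay on MCF-12A cells (Homo sapiens) for inhibition, read by sulforhodamine B assay, with a stated time of 72 h (on this read-out higher numbers stand for weaker inhibition and lower numbers for stronger inhibition), compound 1 gives 1200 nM, the lowest of the two numbers recorded. Its nearest neighbour is compound 2, which in this assay gives 2400 nM; the gap between the two values lies within the usual scatter of this measurement, so the two compounds cannot be put in order on these data. The next compound, compound 3 `COc1cc(OC)c(C(=O)/C=C/c2cn(-c3ccccc3)nc2-c2ccncc2)c(OC)c1`, is built from the same atoms as compound 1, joined differently: pyridin-4-yl in place of pyridin-3-yl on an aromatic carbon. Within the data shown here, no step between two measured compounds is available to show what such a change does here. The expectation is therefore a step from compound 1 to compound 3 of no size beyond the scatter, in no settled direction, as a 1.3-fold higher number from compound 1 to compound 3 (0.10 log units; within the scatter). Compound 3 is estimated to give 1500 nM in this assay, with a range from 600 nM to 4000 nM.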

Compound 3, half-maximal inhibitory concentration: 8200 nM
Estimate against measurement, compound 3: 5.5-fold (0.74 log units) below, and the stated range ends below it.
By their numbers in this assay, from the lowest: compounds 1 and 2 (each within the scatter of the next); then compound 3.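

In this assay, among these compounds, the change to pyridin-4-yl in place of pyridin-3-yl, on the aromatic carbon next to the ring nitrogen, gives a 6.8-fold higher number from compound 1 to compound 3 (0.83 log units; beyond the scatter) and is the first step at this position that lies beyond the scatter. The position therefore responds to where the nitrogen sits within the six-membered aromatic ring, even though the group that leaves and the group that enters have the same heavy atoms and the same counts of donors and acceptors. Nothing measured here accounts for the size of this step.

On these data alone, whether pyridin-2-yl, plain phenyl or a pyridine ring carrying an amine would give a lower or a higher number at this carbon remains open. Also open, as far as these compounds go, is whether the same exchange would give a step of similar size on the core of compound 2.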